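The source may report more compounds than this note shows. Statements on the series, on what has been measured and on what is new or still open speak of the compounds shown alone.

Measured compounds:
- compound 1, `COc1ccc(-c2cn(C/C=C3\OC(=O)C(OCc4ccccc4)=C3OCc3ccccc3)nn2)cc1` — in a functional assay on HCT-116 cells (Homo sapiens) for antiproliferative activity, read by MTT assay, with a stated time of 72 h (a lower number here means a stronger inhibitor, a higher number a weaker inhibitor), compound 1 gives > 100000 nM, which is a limit of the assay.
- compound 2, `O=C1O[C@H]([C@@H](O)Cn2cc(CNS(=O)(=O)c3ccc(F)cc3)nn2)C(OCc2ccccc2)=C1OCc1ccccc1` — in this assay compound 2 gives 22900 nM.
- compound 3, `COc1ccccc1-c1cn(C/C=C2\OC(=O)C(OCc3ccccc3)=C2OCc2ccccc2)nn1` — in this assay compound 3 gives > 100000 nM, again a limit rather than a number.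

Going by the values given here, compound 2 therefore stands as the only compound with a measured number in this assay; the other two sit at the limit of > 100000 nM in this assay, at which 2 of the 3 values shown sit, so no order among the three can be read. Among the compounds with values here, the only step between measured compounds, a step that the two limits leave unreadable from compound 1 to compound 3, is unreadable because both ends are limits, and it concerns a different part of the series anyway.

Compound 4 is `O=C1O[C@H]([C@@H](O)Cn2cc(CNS(=O)(=O)c3ccc(Cl)cc3)nn2)C(OCc2ccccc2)=C1OCc1ccccc1`. It differs from compound 2 by chloro in place of fluoro on an aromatic carbon. Within the data shown here, none of the measured steps bears on this change: no pair of measured compounds differs by chloro in place of fluoro, and the one recorded step gives no size. The expectation for compound 4 therefore rests on compound 2 alone, and the step of a 1.1-fold lower number from compound 2 to compound 4 (0.06 log units; within the scatter) is expected to lie within the usual scatter, with no direction to prefer. Compound 4 is estimated at 20000 nM in this assay, with a range from 7000 nM to 60000 nM.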

Compound 4, half-maximal inhibitory concentration: 8380 nM
Beside the measured number, compound 4's estimate is 2.4-fold (0.38 log units) above it; the measured number falls inside the stated range.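

Chloro in place of fluoro, on an aromatic carbon para to a large group, gives in this assay the first step in the series with a readable size: a 2.7-fold lower number from compound 2 to compound 4 (0.44 log units; beyond the scatter). This shows that the position responds to the exchange of one halogen for another, even though the change brings no ring, no hydrogen-bond donor or acceptor and no net charge, and that the step, though modest, lies beyond the usual scatter. The data shown offer no measured property that would account for this step.

As far as these compounds go, this single pair fixes no trend, so it remains open whether bromo, methyl, methoxy, nitrile, a carboxylic acid or an amine at the same position would continue the step, reverse it or leave the number unchanged. Also open, from the compounds shown here alone, is whether chloro in place of fluoro would give a step of similar size with another link in place of the sulfonylamino group, or on a core other than that of compound 2 and compound 4.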